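A few compounds are considered here, and "the series" means these few. Any claim that something is new, unique, unknown or untested is made for them only; others in the source may bear on it.

Working notes on the series. Compound 2 `COc1cc(-c2cc(/C=C/C(=O)c3ccc(N)cc3)[nH]n2)cc(OC)c1OC` gives -50% in a functional assay on DU-145 cells (Homo sapiens) for cytotoxicity, read by sulforhodamine B assay, with a stated time of 48 h, tested at 10 uM (a lower number here means a stronger effect, a higher number a weaker effect of the compound at the concentration tested), which is the highest of the three numbers in hand. Compound 1 `COc1ccc(-c2cc(/C=C/C(=O)c3ccc(N)cc3)[nH]n2)cc1` gives -55%, a number that sits within the scatter of the value of compound 2. For the measured compounds named here, compound 3 `COc1ccc(C(=O)/C=C/c2cc(-c3cc(OC)c(OC)c(OC)c3)n[nH]2)cc1` gives -93%; the step of a number 43 percentage points lower from compound 2 to compound 3 (beyond the scatter) is the only single-place step measured so far, and it concerns a different change, methoxy in place of amino.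

Compound 4 `COc1ccc(-c2cc(/C=C/C(=O)c3ccc(N)cc3)[nH]n2)cc1OC` is the next compound for this assay. From compound 2 to compound 4 the change is hydrogen in place of methoxy on an aromatic carbon. Going by the values given here, no measured step bears on this change directly: the step of a number 43 percentage points lower from compound 2 to compound 3 (beyond the scatter) alters the amino group, not the methoxy groups. The comparison of compound 1 with compound 2 touches the same ring, since compound 1 carries fewer methoxy groups than compound 2, but the two differ in more than one place and their values lie within the scatter of each other. On that basis no step beyond the scatter is expected in this assay for this change, in either direction. The expected step of a number 2 percentage points lower from compound 2 to compound 4 (within the scatter) is therefore small. Compound 4 is estimated at -52%, with a range from -72% to -32%.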

Compound 4, a percentage reported as activity, at one concentration (the size of the read-out at that concentration, not a potency): 15%
Compound 4: the middle estimate sits 67 percentage points below what was measured, and the stated range ends below it.
By their numbers in this assay, from the lowest: compound 3; then compounds 1 and 2 (each within the scatter of the next); then compound 4.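

In this assay, the methoxy group at this position carries a large effect that the near-equal values of compound 1 (-55%) and compound 2 (-50%) gave no sign of: hydrogen in its place gives a number 65 percentage points higher from compound 2 to compound 4 (beyond the scatter). The opposite kind of change, one more methoxy group on the same ring, also weakens the effect, with a number 70 percentage points higher from compound 1 to compound 4 (beyond the scatter), so adding a methoxy group to this ring has no single direction across the three compounds and its outcome depends on the carbon and on the methoxy groups already present. Nothing at hand accounts for this reversal.

The compounds shown carry only methoxy or hydrogen at this position, so it remains open how a hydroxy group, an ethoxy group or a fluorine atom on the same aromatic carbon would read in this assay. Also open, going by these compounds, is whether hydrogen in place of methoxy has a similar effect when methoxy stands in place of amino on the other aromatic ring, as in compound 3.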